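Cytotoxicity notes on a diaryl-amine series: compound 2 to 3

The compounds below may be only part of what the source reports. "The series", "measured", "known", "first", "only" and "open" are said of these compounds alone.

Measured so far:
compound 1, `COc1nc(Cl)nc(Nc2ccc(Cl)c(OCC=C(C)C)c2)n1`, 26000 nM
compound 2, `CSc1ccnc(Nc2ccc(Cl)c(OCC=C(C)C)c2)n1`, 2800 nM

In an ADME assay on MT2 cells (Homo sapiens) for cytotoxicity (a higher number here means that more compound is tolerated, a lower number that less compound is tolerated), compound 1 gives 26000 nM. In this assay compound 2 gives 2800 nM, the lower of the two numbers; the gap to compound 1 lies beyond the scatter, so compound 2 is the less well tolerated of the pair. Among the compounds with values here, no step between measured compounds that differ in one place is available, so nothing in the measured set tells how a single change on the core of compound 2 moves the read-out.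

Compound 3, `CC(C)=CCOc1cc(Nc2nccc(CO)n2)ccc1Cl`, differs from compound 2 as follows: hydroxymethyl in place of methylsulfanyl on an aromatic carbon. Within the data shown here, with no matching step to lean on, a modest shift toward a higher number is expected for compound 3, at about a 2.1-fold higher number from compound 2 to compound 3 (0.33 log units; beyond the scatter), which would still leave it short of compound 1. The half-maximal cytotoxic concentration of compound 3 in this assay is therefore estimated at 6000 nM, within a range of 2000 nM to 20000 nM.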

Compound 3, half-maximal cytotoxic concentration: 220 nM
Beside the measured number, compound 3's estimate is 27-fold (1.44 log units) above it; the whole stated range lies above it.
By their numbers in this assay, from the lowest: compound 3; then compound 2; then compound 1.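

In this assay hydroxymethyl in place of methylsulfanyl on an aromatic carbon gives a 13-fold lower number from compound 2 to compound 3 (1.10 log units; beyond the scatter) in a single change, a large step. This shows that the position next to the ring nitrogen and meta to a large group is not indifferent in this assay, since one substitution here moves the tolerated concentration well down. The computed difference is small, with sulfur exchanged for oxygen and a hydrogen-bond donor gained, yet nothing available explains why the step is so large.

On these data alone, it remains open whether the lower number follows from the hydroxyl of the new group or from the loss of methylsulfanyl; a methoxymethyl, an aminomethyl, a carboxylic acid or a plain methyl on this carbon would help to separate the two. As far as these compounds go, whether the same exchange moves the read-out similarly on other cores also remains open.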